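Fluoro to methyl on the arylsulfonyl ring of compound 1

This account rests on a few compounds, and the source may have more. Where it says the series, first, only, none or still open, it means among the compounds named here.

Measured in a functional assay (trachea) for antagonist activity, with Cavia porcellus as the target; on this read-out lower numbers stand for lower potency and higher numbers for higher potency (the scale is a negative logarithm):
compound 1 `CCCCC(CC)C(=O)Nc1ccc2ccn(Cc3ccc(C(=O)NS(=O)(=O)c4ccc(F)cc4)cc3OC)c2c1` gives 7.7
compound 2 `COC(=O)C(C(=O)c1ccc(Cn2ncc3ccc(NC(=O)OC4CCCC4)cc32)c(OC)c1)S(=O)(=O)c1ccccc1` gives 9.9
compound 3 `COc1cc(C(=O)NS(=O)(=O)c2ccccc2OC)ccc1Cn1ccc2ccc(NC(=O)CC3CCCC3)cc21` gives 9.7

Compound 1 stands lowest of the three numbers in this assay: compound 3 lies higher by a gap beyond the scatter, and compound 2 lies higher still, also beyond the scatter. Going by the values given here, neither of those two shares a single-point difference with compound 1, so they give no measured step to lean on.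

Compound 4 `CCCCC(CC)C(=O)Nc1ccc2ccn(Cc3ccc(C(=O)NS(=O)(=O)c4ccc(C)cc4)cc3OC)c2c1` differs from compound 1 in one place: methyl in place of fluoro on an aromatic carbon. Among the compounds with values here, no measured pair carries this change. The step from compound 1 to compound 4 in this assay is expected to be no change at the digits printed from compound 1 to compound 4 (within the scatter), nothing beyond the scatter in either direction. Compound 4 is estimated at 7.7, with a range from 7.2 to 8.3.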

Compound 4, negative logarithm of the antagonist equilibrium constant: 8.4
Beside the measured number, compound 4's estimate is 0.70 log units below it; the whole stated range lies below it.
By their numbers in this assay, from the lowest: compound 1; then compound 4; then compounds 3 and 2 (each within the scatter of the next).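

In this assay, going by these compounds alone, the change from 4-fluorophenyl to 4-methylphenyl gives a number 0.70 log units higher from compound 1 to compound 4 (beyond the scatter), the first single-place step. The substituent on this ring therefore affects the read-out, even though the exchange swaps one heavy atom for one heavy atom and leaves the counts of hydrogen-bond donors and acceptors unchanged. Nothing available bears on the origin of this step.

The compounds shown leave open how chloro, trifluoromethyl or a longer chain such as ethyl would fare at this place. They also leave open whether the same exchange gives a similar step with other amide side chains.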